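This account rests on a few compounds, and the source may have more. Where it says the series, first, only, none or still open, it means among the compounds named here.

Tested in an ADME assay on cells (Epithelial cell, Homo sapiens) for cytotoxicity, read by MTT assay, with a stated time of 44 h (a lower number here means a stronger inhibitor, a higher number a weaker inhibitor), compound 1 `CCc1ccccc1C1CC(c2ccccc2)=NN1C(N)=S` gives > 50000 nM as its result, and this is a limit of the assay rather than a number. Compound 2 `CC(C)c1ccccc1/C=C/C(=O)c1ccccc1` likewise yields only a limit at > 46000 nM in this assay and no number. Within the data shown here, no measured step is therefore available as a guide. Compound 3 `CC(C)c1ccccc1C1CC(c2ccccc2)=NN1C(N)=S` departs from compound 1 by a single change methyl in place of hydrogen on a saturated chain carbon bound to an aromatic carbon and a saturated chain carbon that puts methyl in place of hydrogen on a saturated chain carbon bound to an aromatic carbon and a saturated chain carbon, which also reads as ethyl to isopropyl. With compound 1 resting at the limit > 50000 nM in this assay no shift beyond the usual scatter is expected. The expected step of a number no higher from compound 1 to compound 3 (the limit leaves the size open) is estimated to be small and without a clear direction. Compound 3 is estimated at 50000 nM with an expected range from 25000 nM to 100000 nM and here too a limit rather than a number is expected.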

Compound 3, half-maximal inhibitory concentration: > 50000 nM
Compound 3 ended at the assay's limit; the forecaster's own chance of this, stated with the estimate: 75%; the middle value lies on the limit itself.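

Compound 1 and compound 3 both rest at a limit of the assay in this assay, and the step between them cannot be read: the limit of > 50000 nM in this assay, at which 2 of the 3 values shown sit. The compounds shown leave open how large the change from ethyl to isopropyl is in this assay, and whether any compound here would give a number rather than a limit.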